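A few compounds are considered here, and "the series" means these few. Any claim that something is new, unique, unknown or untested is made for them only; others in the source may bear on it.

Measured compounds:
compound 1 `Cc1cccc(C)c1-c1cccc(COc2ccc(CCC(=O)O)cn2)c1`, 38 nM
compound 2 `Cc1cccc(C)c1-c1cccc(COc2ccc(CCC(=O)O)c(C)n2)c1`, 1100 nM

Going by the values given here, in a functional assay on CHO cells for agonist activity at Free fatty acid receptor 1 (Rattus norvegicus), read by calcium flux (on this read-out higher numbers stand for an effect only at larger amounts of compound and lower numbers for an effect already at smaller amounts), compound 1 gives the lower of the two numbers; the only measured step, a 29-fold higher number from compound 1 to compound 2 (1.46 log units; beyond the scatter), places a methyl on the core. Compound 3 `Cc1cc(CCC(=O)O)cnc1OCc1cccc(-c2c(C)cccc2C)c1` differs from compound 1 by methyl in place of hydrogen on an aromatic carbon, a methyl on a different ring carbon than in compound 2. Among the compounds with values here, the step from compound 1 to compound 2 is the sole bearing on this change and was large; a higher number for compound 3 is therefore expected, a 5.3-fold higher number from compound 1 to compound 3 (0.72 log units; beyond the scatter), though with wide uncertainty. Compound 3 is estimated at 200 nM, range 40 nM to 1000 nM.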

Compound 3, half-maximal effective concentration: 9100 nM
For compound 3 the middle estimate is 46-fold (1.66 log units) below the measured one, outside the stated range (above it).
By their numbers in this assay, from the lowest: compound 1; then compound 2; then compound 3.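

In this assay, methyl in place of hydrogen on this aromatic carbon, ortho to a large group and two atoms from the ring nitrogen, gives a 240-fold higher number from compound 1 to compound 3 (2.38 log units; beyond the scatter) and so exceeds the other methyl step, a 29-fold higher number from compound 1 to compound 2 (1.46 log units; beyond the scatter). Of the two ring carbons carrying a methyl in these compounds, this one shows the larger rise in the number. Nothing available explains the size of this step.

Still open, from the compounds shown here alone, is whether a fluorine atom or a methoxy group on this carbon would give a step of similar size. The compounds shown also leave open whether a chlorine atom there would do so.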